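From 3-iodophenyl to 4-iodophenyl: an expected step

The source may report more compounds than this note shows. Statements on the series, on what has been measured and on what is new or still open speak of the compounds shown alone.

Measured in a functional assay on B16 cells (Mus musculus) for cytotoxicity, read by CCK-8 assay, with a stated time of 24 h; a lower number here means a stronger inhibitor, a higher number a weaker inhibitor:
Compound 1 `COc1ccccc1Oc1c(N)nc(-c2ccccc2F)nc1Cl`: 13800 nM
Compound 2 `COc1ccccc1Oc1c(N)nc(-c2cccc(I)c2)nc1Cl`: 27600 nM

Going by the values given here, compound 2, at 27600 nM, cannot be told apart from compound 1, the only other compound measured. Compound 3 `COc1ccccc1Oc1c(N)nc(-c2ccc(I)cc2)nc1Cl` carries 4-iodophenyl in place of 3-iodophenyl on an aromatic carbon. Among the compounds with values here, the one measured step that bears on this change, a 2.0-fold higher number from compound 1 to compound 2 (0.30 log units; within the scatter), replaced 2-fluorophenyl with 3-iodophenyl at the same place. Within the data shown here, no measured step moves the iodine alone, so the evidence is indirect. No step beyond the scatter is therefore expected in this assay. The estimated change is a 1.3-fold lower number from compound 2 to compound 3 (0.10 log units; within the scatter). Compound 3 is expected at 22000 nM, with an estimated range of 10000 nM to 50000 nM.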

Compound 3, half-maximal inhibitory concentration: 5400 nM
Beside the measured number, compound 3's estimate is 4.1-fold (0.61 log units) above it, outside the stated range (below it).
By their numbers in this assay, from the lowest: compound 3; then compounds 1 and 2 (each within the scatter of the next).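

In this assay, moving the iodine alone gives a 5.1-fold lower number from compound 2 to compound 3 (0.71 log units; beyond the scatter) and so lies beyond the scatter. This shows that the place of the iodine on this phenyl group matters here, which the earlier step from 2-fluorophenyl to 3-iodophenyl could not show. 4-iodophenyl also separates from 2-fluorophenyl, with a 2.6-fold lower number from compound 1 to compound 3 (0.41 log units; beyond the scatter) in the same assay. Nothing given here accounts for the shift. The compounds shown leave open whether the lower number depends on iodine itself, or whether 4-bromophenyl or 4-aminophenyl would read like 4-iodophenyl.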